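Phenyl variation at the end of the double-bonded chain

The compounds below may be only part of what the source reports. "The series", "measured", "known", "first", "only" and "open" are said of these compounds alone.

Compound 1 `O=C(/C=C/c1cccc(Cl)c1Cl)Nc1cc2c(Nc3ccc(F)c(Cl)c3)ncnc2cc1O[C@H]1CCOC1` is measured in a functional assay on MCF7 cells (Homo sapiens) for cytotoxicity, read by MTT assay, with a stated time of 72 h (a higher number here means a weaker inhibitor, a lower number a stronger inhibitor), and gives 30100 nM. Compound 3 `O=C(/C=C/c1ccc(Br)cc1)Nc1cc2c(Nc3ccc(F)c(Cl)c3)ncnc2cc1O[C@H]1CCOC1` is its nearest neighbour on the same core; compound 3 gives 32400 nM, and the two values sit within the scatter of each other, so no order between compound 1 and compound 3 can be read. Compound 2 `COc1cc2ncnc(Nc3ccc(F)c(Cl)c3)c2cc1NC(=O)/C=C/c1ccc(C#N)cc1` carries a methoxy group on the core in place of the cyclic ether and gives "not active" (no number reported), without a number, so it offers no quantitative anchor.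

Compound 4 `O=C(/C=C/c1ccc(F)cc1Cl)Nc1cc2c(Nc3ccc(F)c(Cl)c3)ncnc2cc1O[C@H]1CCOC1` differs from compound 1 only at the phenyl on the double-bonded chain: 2-chloro-4-fluorophenyl in place of 2,3-dichlorophenyl on a double-bonded chain carbon bound to a double-bonded chain carbon. Going by the values given here, the one measured step of the same kind, a 1.1-fold higher number from compound 1 to compound 3 (0.03 log units; within the scatter), shows that exchanging one substituted phenyl for another at this place stayed within the scatter. Nothing in the series points to a larger effect for the 2-chloro-4-fluorophenyl.

The estimate for compound 4 is therefore flat: a 1.1-fold higher number from compound 1 to compound 4 (0.03 log units; within the scatter), with compound 4 expected near 32000 nM, in the range 15000 nM to 70000 nM.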

Compound 4, half-maximal inhibitory concentration: 26200 nM
Beside the measured number, compound 4's estimate is 1.2-fold (0.09 log units) above it; the range from low to high includes it.
By their numbers in this assay, from the lowest: compounds 4, 1 and 3 (each within the scatter of the next).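

In this assay, 2-chloro-4-fluorophenyl in place of the earlier groups gives a 1.1-fold lower number from compound 1 to compound 4 (0.06 log units; within the scatter) and a 1.2-fold lower number from compound 3 to compound 4 (0.09 log units; within the scatter) at this place, on a double-bonded chain carbon bound to a double-bonded chain carbon. A single pair of compounds had shown a flat step here; compound 1, compound 3 and compound 4 now form a set of three on the shared core that cannot be ordered, and the set includes a fluorine-bearing phenyl. No measurement at hand accounts for this flat result.

From the compounds shown here alone, all three groups here are halogen-bearing phenyls, and the values for an unsubstituted phenyl, an aminophenyl or a carboxylic acid on the ring remain open. Also open, going by these compounds, is whether a saturated alkyl chain in place of the phenyl stays within this narrow range.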